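The 3,4-dichlorophenyl change on compound 2

The compounds below may be only part of what the source reports. "The series", "measured", "known", "first", "only" and "open" are said of these compounds alone.

In a functional assay on HepG2 cells (Homo sapiens) for cytotoxicity, read by MTT assay, with a stated time of 48 h (on this read-out higher numbers stand for weaker inhibition and lower numbers for stronger inhibition), compound 2 (`COC(=O)/C=C/c1ccc2c(c1)C(=O)C(=O)N2Cc1ccccc1`) gives 40 nM and holds the lower of the two numbers measured. Compound 3 (`COC(=O)/C=C/c1ccc2c(c1)C(=O)C(=O)N2`) gives 370 nM and is the nearest value to compound 2. Compound 1 (`COC(=O)/C=C/c1ccc2c(c1)N(Cc1ccc(OC)cc1)C(=O)C2=O`) returns only a limit of the assay (> 10000 nM) and so provides no number.

Compound 4 (`COC(=O)/C=C/c1ccc2c(c1)C(=O)C(=O)N2Cc1ccc(Cl)c(Cl)c1`) has not yet been measured. It departs from compound 2 by a single change (3,4-dichlorophenyl in place of phenyl on a saturated chain carbon bound to an amide-type nitrogen in a ring), with 3,4-dichlorophenyl in place of phenyl on a saturated chain carbon bound to an amide-type nitrogen in a ring. Among the measured compounds shown here, the one measured step at that nitrogen is modest but beyond the scatter (a 9.3-fold higher number from compound 2 to compound 3 (0.97 log units; beyond the scatter)), and it removes the benzyl group entirely, leaving hydrogen. Compound 4 keeps the chain carbon and its aromatic ring, so that step does not set the size of this narrower change. For the measured compounds named here, compound 1 is joined to compound 2 by no single-place step and gives no guide here. The expectation in this assay is therefore for no step beyond the scatter, and the estimated step is small (no change at the digits printed from compound 2 to compound 4 (within the scatter)) in either direction. The estimate for compound 4 is 40 nM with an expected range from 12 nM to 130 nM on this read-out.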

Compound 4, half-maximal inhibitory concentration: 160 nM
Compound 4: middle estimate off by 4.0-fold (0.60 log units), on the low side, and the stated range ends below it.
By their numbers in this assay, from the lowest: compound 2; then compound 4; then compound 3. At a limit, above all of these: compound 1.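

In this assay, the aromatic ring of the benzyl group proves sensitive to substitution: with the chain carbon and the ring both kept, the change to 3,4-dichlorophenyl alone gives a step beyond the scatter (a 4.0-fold higher number from compound 2 to compound 4 (0.60 log units; beyond the scatter)). Among the compounds shown here, the only earlier step at this nitrogen removed the whole benzyl group (a 9.3-fold higher number from compound 2 to compound 3 (0.97 log units; beyond the scatter)), so it could not show whether a change on the ring itself, short of removal, would move the number. The printed values also place the new compound between the two earlier ones, as compound 4 gives 160 nM and compound 3 gives the higher 370 nM, so here the substituted benzyl group still gives a lower number than hydrogen on that nitrogen.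

No measurement given here bears on what lies behind the step from phenyl to 3,4-dichlorophenyl. As far as these compounds go, it remains open whether a single chlorine, a fluorine or an amine on that ring, or a longer chain between the nitrogen and the ring, would give a similar step or a different one.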